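The source may hold more compounds than are shown below. What is called first, only, known or untested is meant among the compounds shown, and "the series" means these compounds.

Measured compounds:
- compound 1 `COc1ccc(NC(=O)Nc2ccc(Nc3ncnc4c3OCCN4)cc2)cc1`: 227 nM
- compound 2 `Cc1ccc(F)c(NC(=O)Nc2ccc(Nc3ncnc4c3OCCN4)cc2)c1`: 1470 nM

Going by the values given here, in an assay on isolated protein for inhibition of proto-oncogene tyrosine-protein kinase receptor Ret (Homo sapiens), read by 33P incorporation, with stated times of 15 min and 40 min (on this read-out higher numbers stand for weaker inhibition and lower numbers for stronger inhibition), compound 2 gives the higher of the two numbers; the only measured step, a 6.5-fold higher number from compound 1 to compound 2 (0.81 log units; beyond the scatter), puts it beyond the scatter from compound 1. Compound 3 `O=C(Nc1ccc(Nc2ncnc3c2OCCN3)cc1)Nc1cc(Cl)cc(Cl)c1` carries the change (3,5-dichlorophenyl in place of 2-fluoro-5-methylphenyl on an amide-type nitrogen), where the amide-type nitrogen's other neighbour is the carbonyl carbon. Among the compounds with values here, no measured step exchanges one substituted phenyl for another of this kind, so the step from compound 1 to compound 2 bears only loosely on it. For compound 3 in this assay the expected number is 900 nM (range 200 nM to 3500 nM), an expected step of a 1.6-fold lower number from compound 2 to compound 3 (0.21 log units; within the scatter), not beyond the scatter.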

Compound 3, half-maximal inhibitory concentration: 865 nM
Compound 3: middle estimate off by 1.0-fold (0.02 log units), on the high side; the measured number falls inside the stated range.
By their numbers in this assay, from the lowest: compound 1; then compounds 3 and 2 (each within the scatter of the next).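

In this assay, 3,5-dichlorophenyl in place of 2-fluoro-5-methylphenyl on the amide-type nitrogen gives a 1.7-fold lower number from compound 2 to compound 3 (0.23 log units; within the scatter), so this exchange of substituted phenyls separates nothing here. Exchanging 4-methoxyphenyl for 3,5-dichlorophenyl gives a 3.8-fold higher number from compound 1 to compound 3 (0.58 log units; beyond the scatter), so the gap seen with 2-fluoro-5-methylphenyl also appears with a second, differently substituted ring. No measurement on hand accounts for this gap.

Still open, from the compounds shown here alone, is whether the methoxy group itself sets compound 1 apart. A plain phenyl, or a phenyl carrying an amine or a carboxylic acid, would test this at the same nitrogen.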